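The source may hold more compounds than are shown below. What is called first, only, known or untested is meant among the compounds shown, and "the series" means these compounds.

Measured so far in a functional assay on HepG2 cells (Homo sapiens) for cytotoxicity, read by MTT assay, with a stated time of 72 h; on this read-out higher numbers stand for weaker inhibition and lower numbers for stronger inhibition:
- Compound 1 `C#Cc1cccc(Nc2nc3cnc(Nc4ccc(N5CCN(C)CC5)cc4)nc3n2C2CCCC2)c1`: 4900 nM
- Compound 2 `CN1CCN(c2ccc(Nc3ncc4nc(Nc5ccc(Br)cc5F)n(C5CCCC5)c4n3)cc2)CC1`: > 5000 nM

Compound 2 gives > 5000 nM, which is a limit of the assay and not a number. The evidence on this is thin: the limit of > 5000 nM in this assay, at which 1 of the 2 values shown sits.

Compound 3 `CN1CCN(c2ccc(Nc3ncc4nc(Nc5cc(Cl)ccc5Cl)n(C5CCCC5)c4n3)cc2)CC1` has 2,5-dichlorophenyl in place of 4-bromo-2-fluorophenyl on a nitrogen on an aromatic ring.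

Within the data shown here, one measured step bears on this, a swap of the group at the same place: an at least 1.0-fold higher number from compound 1 to compound 2 (0.00 log units; that floor lies within the scatter). It gives only a floor for the size of the change, and no larger change is shown. On that single step, no step beyond the scatter is expected in this assay, and another limit is quite possible. The expected step is a step that the limit leaves unreadable from compound 2 to compound 3. For compound 3 the estimated value is 6000 nM, with an expected range of 3000 nM to 12000 nM.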

Compound 3, half-maximal inhibitory concentration: > 5000 nM
Compound 3: no number, only a limit; the forecaster's own chance of this, stated with the estimate: 60%; the middle value is on the limit's open side.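

In this assay compound 3 gives > 5000 nM, which is a limit of the assay and not a number. Putting 2,5-dichlorophenyl in place of 3-ethynylphenyl on a nitrogen on an aromatic ring gives an at least 1.0-fold higher number from compound 1 to compound 3 (0.00 log units; that floor lies within the scatter), so no change beyond the scatter can be claimed for this swap. The step between the two halogen-bearing compounds cannot be read, and a second group at this place now yields no number: the limit of > 5000 nM in this assay, at which 2 of the 3 values shown sit.

Among these compounds, compound 1, at 4900 nM, holds the only actual number, so no order among the three groups can be given. Going by these compounds, whether a phenyl group carrying an amine or a carboxylic acid at this place would give a readable number in this assay remains open.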